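Amino Substitution on the Thiophene Ketone Terminus

The compounds below may be only part of what the source reports. "The series", "measured", "known", "first", "only" and "open" are said of these compounds alone.

compound 1 `COc1ccc(-c2cc3ccccc3nc2/C=C/C(=O)c2ccc(N)cc2)cc1`: 6920 nM
compound 2 `COc1ccc(-c2cc3ccccc3nc2/C=C/C(=O)c2ccsc2)cc1`: 6010 nM

In a functional assay on MCF7 cells (Homo sapiens) for antiproliferative activity, read by XTT assay, with a stated time of 72 h (on this read-out lower numbers stand for stronger inhibition and higher numbers for weaker inhibition), compound 2 holds the lowest of the two numbers, and its nearest neighbour is compound 1, with a 1.2-fold lower number from compound 1 to compound 2 (0.06 log units; within the scatter) separating them. Compound 3 `COc1ccc(-c2cc3ccccc3nc2/C=C/C(=O)c2sccc2N)cc1` is reached from compound 2 by 3-aminothiophen-2-yl in place of thiophen-3-yl on a carbonyl carbon. Going by the values given here, the only measured step that touches this position, a 1.2-fold lower number from compound 1 to compound 2 (0.06 log units; within the scatter), swapped a ring carrying an amino group for one without it and stayed within the scatter, so an added amino group here is expected to move the number little. Compound 3 is therefore estimated at 6000 nM, within 2500 nM to 15000 nM, a step of a 1.0-fold lower number from compound 2 to compound 3 (0.00 log units; within the scatter).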

Compound 3, half-maximal inhibitory concentration: > 10000 nM
Compound 3: a limit, no number (the forecaster's own chance of this, stated with the estimate: 10%); middle value at least 1.6-fold (0.22 log units) from the limit.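

Compound 3 gives only a limit of the assay in this assay, not a number: the limit of > 10000 nM in this assay, at which 1 of the 3 values shown sits.

On this carbonyl carbon, 3-aminothiophen-2-yl gives an at least 1.6-fold higher number from compound 2 to compound 3 (0.22 log units; that floor lies within the scatter), and against the 4-aminophenyl group it gives an at least 1.4-fold higher number from compound 1 to compound 3 (0.15 log units; that floor lies within the scatter). Unlike the earlier pair, this change therefore has only a floor, so it shows no gain in inhibition, and its true size remains undetermined.

From the compounds shown here alone, what a thiophen-2-yl group without the amine would give on this carbonyl carbon stays open. So does whether the amine or the different linkage of the thiophene accounts for the result.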